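Extending the Selenoester Tail of a Carboxypeptidase B Inhibitor

The source may report more compounds than this note shows. Statements on the series, on what has been measured and on what is new or still open speak of the compounds shown alone.

The measure here is an assay on isolated protein for inhibition of carboxypeptidase B (Sus scrofa), read by spectrophotometry, with stated times of 10 min and 30 min, in the presence of a further agent that is not named here; a higher number here means a weaker inhibitor, a lower number a stronger inhibitor. Of the compounds shown here, two have been measured. Compound 1 `CCOC(=O)C(C[Se]C(=O)CC)Cc1cnc(N)c(Cl)c1` gives 130000 nM in this assay, and compound 2 `NCCCCCC(C[Se]C(=O)CCc1ccccc1)C(=O)O` gives 3.2 nM, the lower of the two numbers and far apart from the figure for compound 1. The next compound is compound 3 `NCCCCCC(C[Se]C(=O)CCCc1ccccc1)C(=O)O`, which differs from compound 2 in one place: benzyl in place of phenyl on a saturated chain carbon, two bonds along the chain from a carbonyl carbon. Among the measured compounds shown here, no measured pair shows this change, so its effect can only be expected rather than read off. One further chain carbon between the carbonyl and the aromatic ring, with nothing else altered, is expected to leave the number for compound 3 close to that of compound 2, so the expected step in this assay a 1.3-fold higher number from compound 2 to compound 3 (0.10 log units; within the scatter) is none beyond the scatter. Compound 3 is thus estimated at 4 nM, in a range from 1.5 nM to 12 nM.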

Compound 3, half-maximal inhibitory concentration: 3.2 nM
Estimate against measurement, compound 3: 1.3-fold (0.10 log units) above; the range from low to high includes it.
By their numbers in this assay, from the lowest: compounds 2 and 3 (each within the scatter of the next); then compound 1.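

In this assay, among the compounds shown here, the change gives no change at the digits printed from compound 2 to compound 3 (within the scatter) and is the first step that can be read in one place, since compound 1 differs from compound 2 in more than one. It shows that on a saturated chain carbon, two bonds along the chain from a carbonyl carbon, benzyl can stand in place of phenyl without the number moving beyond the scatter. Nothing given here bears on why the number holds.

As far as these compounds go, whether a longer chain in place of benzyl would still leave the number unmoved remains open, so the limit of this tolerance is not yet known. Also open, from the compounds shown here alone, is what an amine or a carboxylic acid carried on the benzyl group would do to the number.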